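A Halogenated Methyl in Place of a Butyl Chain

A few compounds are considered here, and "the series" means these few. Any claim that something is new, unique, unknown or untested is made for them only; others in the source may bear on it.

Of the compounds shown here, two have so far been measured in an assay on mitochondria from L6 cells (Rattus norvegicus) for activation, with a stated time of 90 min; on this read-out higher numbers stand for an effect only at larger amounts of compound and lower numbers for an effect already at smaller amounts. Compound 1 `Fc1cccc(Nc2nc3nonc3nc2Nc2ccccc2F)c1` gives 190 nM in this assay, while compound 2 `CCCCOc1ccc(Nc2nc3nonc3nc2O)cc1` gives 3700 nM in this assay. Of the two numbers recorded, compound 2 stands at the higher one, and its gap to compound 1 lies beyond the usual scatter of repeated measurements of this kind.

Compound 3 `Oc1nc2nonc2nc1Nc1ccc(OC(F)(F)Cl)cc1` has not yet been measured in this assay. Within the data shown here, it differs from compound 2 in a single place, which the following line describes. chloro(difluoro)methyl in place of butyl on an oxygen on an aromatic ring No measured pair shows what this exchange does on this read-out, so the direction of any step rests on no recorded precedent within the set. The account therefore expects only a modest movement, within or near the scatter, with the step from compound 2 to compound 3 estimated as a 1.2-fold lower number from compound 2 to compound 3 (0.09 log units; within the scatter). Compound 3 is accordingly expected to give about 3000 nM in this assay, with a range from 1000 nM to 10000 nM.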

Compound 3, half-maximal effective concentration: 1900 nM
For compound 3 the middle estimate is 1.6-fold (0.20 log units) above the measured one; the range from low to high includes it.
By their numbers in this assay, from the lowest: compound 1; then compounds 3 and 2 (each within the scatter of the next).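

Read in this assay the exchange of butyl for chloro(difluoro)methyl on an oxygen on an aromatic ring amounts to a 1.9-fold lower number from compound 2 to compound 3 (0.29 log units; within the scatter) and so cannot be told apart from no change on this read-out. Among these compounds, this is the first pair in the set that differs in one place, and it shows that this oxygen can carry either a four-carbon chain or a single carbon bearing two fluorines and a chlorine while the two compounds stay within the usual scatter of each other. The butyl chain itself is thus not needed for a value of this size, although this rests on one pair and no measured property of either group accounts for the result.

The compounds shown leave open what a smaller or a longer group on this oxygen would do, such as a plain methyl, a trifluoromethyl or an octyl chain, and whether a free hydroxyl in its place would hold a value of this size. They also leave open whether an amine or a carboxylic acid at this place on the aromatic ring would move the number beyond the scatter.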